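The compounds below may be only part of what the source reports. "The series", "measured", "known", "first", "only" and "open" are said of these compounds alone.

Measured compounds in a functional assay on the whole organism (Central nervous system) for activation, with Mus musculus as the target; on this read-out lower numbers stand for an effect already at smaller amounts and higher numbers for an effect only at larger amounts of compound:

Compound 1 `COc1ccc(C23CCC(=O)N2CCCO3)cc1` — compound 1 gives only a limit of the assay, < 150 mg/kg.
Compound 2 `O=C1CCC2(c3ccc(Cl)cc3)OCCCN12` — compound 2 gives 75 mg/kg.
Compound 3 `O=C(CCC(=O)c1ccc(Cl)cc1)NCCCO` — compound 3 gives 300 mg/kg.

Compound 3 stands at the highest of the two numbers; its nearest neighbour is compound 2, and the gap between the two is beyond the usual scatter. How the core of compound 3 differs from the core of compound 2 is not broken down here.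

The change from compound 2 to compound 1 is methoxy in place of chloro on an aromatic carbon. Its size, a step that the limit leaves unreadable from compound 2 to compound 1, cannot be read because of the limit of < 150 mg/kg in this assay, at which 1 of the 3 values shown sits.

The unmeasured compound 4 `COc1ccc(C(=O)CCC(=O)NCCCO)cc1` differs from compound 3 by methoxy in place of chloro on an aromatic carbon, the same kind of change as from compound 2 to compound 1, at a place described in the same words.

Going by the values given here, as the only earlier step of this kind, a step that the limit leaves unreadable from compound 2 to compound 1, gives no readable size, the step expected from compound 3 to compound 4 is set near nil, no change at the digits printed from compound 3 to compound 4 (within the scatter), with wide bounds. Compound 4 is thus estimated at 300 mg/kg, expected between 150 mg/kg and 600 mg/kg.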

Compound 4, dose for half-maximal effect: 150 mg/kg
Estimate against measurement, compound 4: 2.0-fold (0.30 log units) above; the range from low to high includes it.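

In this assay, methoxy in place of chloro on an aromatic carbon, para to a large group, gives a 2.0-fold lower number from compound 3 to compound 4 (0.30 log units; within the scatter), so on the core of compound 3 this change produces no shift that can be told from the scatter. On the core of compound 2 the same change cannot be read, and compound 1 stands as a limit only: the limit of < 150 mg/kg in this assay, at which 1 of the 4 values shown sits. This leaves a single readable step, which shows how the change behaves on one core but neither confirms nor rules out that the result carries over to the other.

Still open, on these data alone, is how other groups on that aromatic carbon, such as fluoro, trifluoromethyl or an amine, would read on either core. Also open, as far as these compounds go, is what a carboxylic acid in place of the hydroxyl of compound 3 and compound 4, or a longer chain between that hydroxyl and the amide nitrogen, would do in this read-out.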